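Propyl in place of methyl on the uracil-like ring

This account rests on a few compounds, and the source may have more. Where it says the series, first, only, none or still open, it means among the compounds named here.

Compound 1: `Cn1c(=O)ccn([C@@H]2O[C@H](COP(=O)(O)OP(=O)(O)OP(=O)(O)O)[C@@H](O)[C@H]2O)c1=O`, 564 nM
Compound 2: `Cc1cc(=O)n([C@@H]2O[C@H](COP(=O)(O)OP(=O)(O)OP(=O)(O)O)[C@@H](O)[C@H]2O)c(=O)[nH]1`, > 1000 nM

Compound 1 gives 564 nM in an in vitro functional assay on 1321-N1 cells for agonist activity at P2Y purinoceptor 2 (Homo sapiens); on this read-out lower numbers stand for an effect already at smaller amounts and higher numbers for an effect only at larger amounts of compound. Compound 2 reaches only the assay limit of > 1000 nM in this assay, so for compound 2 only a floor is known, set by the limit of > 1000 nM in this assay, at which 1 of the 2 values shown sits. For the measured compounds named here, the one measured step, an at least 1.7-fold higher number from compound 1 to compound 2 (0.24 log units; that floor lies within the scatter), swaps one heterocycle for another and does not speak to the change at hand.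

Compound 3, `CCCc1cc(=O)n([C@@H]2O[C@H](COP(=O)(O)OP(=O)(O)OP(=O)(O)O)[C@@H](O)[C@H]2O)c(=O)[nH]1`, differs from compound 2 by ethyl in place of hydrogen on a saturated chain carbon bound to an aromatic carbon. Going by the values given here, no measured step tests an alkyl chain at this place, so the expectation rests on compound 2 alone: since compound 2 stands at the limit, compound 3 is expected to remain at or beyond it, with an expected step that the limit leaves unreadable from compound 2 to compound 3. Compound 3 is therefore estimated at 3000 nM, within 1000 nM to 10000 nM.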

Compound 3, half-maximal effective concentration: > 1000 nM
Compound 3: only a limit was reported (the forecaster's own chance of this, stated with the estimate: 75%); the middle value lies beyond the limit too.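

For the compounds shown here, compound 2 and compound 3 both stand only as limits of the assay, so no step between them can be read. In this assay the compounds shown leave open whether ethyl in place of hydrogen changes the effect, and in which direction and how far.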